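The compounds below may be only part of what the source reports. "The series", "measured", "known", "first", "only" and "open" are said of these compounds alone.

Compound 1 `COc1ccc(/C=C2\SC(=O)N(Cc3ccc(C(=O)O)cc3)C2=O)cc1`: 44000 nM in a functional assay on HT-29 cells (Homo sapiens) for cytotoxicity, read by MTT assay, with a stated time of 24 h; a lower number here means a stronger inhibitor, a higher number a weaker inhibitor. Compound 2 `O=C(O)c1ccc(CN2C(=O)S/C(=C\c3ccccc3)C2=O)cc1`: 88000 nM. Compound 3 `O=C(O)c1ccc(CN2C(=O)S/C(=C\c3cccs3)C2=O)cc1`: 88000 nM.

On these numbers compound 3 sits level with compound 2 at the digits shown, and the remaining gap is a 2.0-fold higher number from compound 1 to compound 3 (0.30 log units; within the scatter), so all three lie within the usual spread of this assay. Compound 4 `Cn1cccc1/C=C1\SC(=O)N(Cc2ccc(C(=O)O)cc2)C1=O` is not yet measured; it differs from compound 3 in one place: 1-methyl-1H-pyrrol-2-yl in place of thiophen-2-yl on a double-bonded chain carbon bound to a double-bonded ring carbon. The step that bears most directly on it is the exchange of phenyl for thiophen-2-yl, no change at the digits printed from compound 2 to compound 3 (within the scatter); the other steps, a 2.0-fold higher number from compound 1 to compound 2 (0.30 log units; within the scatter) and a 2.0-fold higher number from compound 1 to compound 3 (0.30 log units; within the scatter), were likewise small. Swapping one five-membered aromatic ring with one hetero atom for another is therefore expected to give no step beyond the scatter in this assay. Compound 4 is estimated at 80000 nM, with a likely range from 30000 nM to 200000 nM. This means an expected step of a 1.1-fold lower number from compound 3 to compound 4 (0.04 log units; within the scatter).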

Compound 4, half-maximal inhibitory concentration: 88000 nM
Beside the measured number, compound 4's estimate is 1.1-fold (0.04 log units) below it; measured number inside the range.
By their numbers in this assay, from the lowest: compounds 1, 2, 3 and 4 (each within the scatter of the next).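

In this assay 1-methyl-1H-pyrrol-2-yl in place of thiophen-2-yl gives no change at the digits printed from compound 3 to compound 4 (within the scatter) and in place of phenyl gives no change at the digits printed from compound 2 to compound 4 (within the scatter) while in place of 4-methoxyphenyl it gives a 2.0-fold higher number from compound 1 to compound 4 (0.30 log units; within the scatter) and so adds a third comparison to the set. This position, on a double-bonded chain carbon bound to a double-bonded ring carbon, therefore takes a ring nitrogen bearing a methyl group with no step beyond the scatter. The compounds shown leave open whether an amine or a nitro group on this aromatic ring, or a longer chain in its place, would move the number beyond the scatter. No measured evidence gives a reason for these flat results.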